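Cytotoxicity notes: side-chain change from compound 1 to compound 4

The compounds below may be only part of what the source reports. "The series", "measured", "known", "first", "only" and "open" are said of these compounds alone.

Three measured members of the series share one core and differ only in the group on the aromatic carbon. Compound 1 `Cc1cc(C)cc(S(=O)(=O)c2c(C(=O)NCN3CCCCC3)[nH]c3ccc([N+](=O)[O-])cc23)c1` carries the nitro group; in an ADME assay on CCRF-CEM cells (Homo sapiens) for cytotoxicity, read by cell counting (on this read-out lower numbers stand for higher toxicity in this test and higher numbers for lower toxicity in this test), compound 1 gives 12000 nM, the highest of the three numbers. Compound 2 `Cc1cc(C)cc(S(=O)(=O)c2c(C(=O)NCN3CCCCC3)[nH]c3ccc(Br)cc23)c1` carries bromo and gives 10000 nM in this assay; compound 3 `Cc1cc(C)cc(S(=O)(=O)c2c(C(=O)NCN3CCCCC3)[nH]c3ccc(Cl)cc23)c1` carries chloro and gives 9900 nM. The steps are a 1.2-fold lower number from compound 1 to compound 2 (0.08 log units; within the scatter), a 1.2-fold lower number from compound 1 to compound 3 (0.08 log units; within the scatter) and a 1.0-fold lower number from compound 2 to compound 3 (0.00 log units; within the scatter); all three lie within the scatter, so among these compounds the choice of group on the aromatic carbon does not move the number beyond the scatter.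

Compound 4 `Cc1cc(C)cc(S(=O)(=O)c2c(C(=O)NCCOc3ccccc3)[nH]c3ccc([N+](=O)[O-])cc23)c1` keeps the nitro group of compound 1 and changes the amide side chain: phenoxymethyl in place of piperidin-1-yl on a saturated chain carbon bound to an amide-type nitrogen. Within the data shown here, none of the measured steps touches this part of the molecule, so no measured step bears directly on it; the only guide is that the series so far sits in a narrow band. Compound 4 is therefore expected to stay close to that band, and the estimated step is no change at the digits printed from compound 1 to compound 4 (within the scatter). The estimate for compound 4 is 12000 nM, with a range from 4000 nM to 36000 nM. Among the measured compounds shown here, the range is kept wide: no measured step covers this side chain.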

Compound 4, half-maximal cytotoxic concentration: > 500000 nM
Compound 4 gave a limit, no number (the forecaster's own chance of this, stated with the estimate: 20%); middle value at least 41-fold (1.61 log units) away from the limit.
By their numbers in this assay, from the lowest: compounds 3, 2 and 1 (each within the scatter of the next). At a limit, above all of these: compound 4.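

In this assay, the amide side chain matters far more than the group on the aromatic carbon, with an at least 41-fold higher number from compound 1 to compound 4 (1.61 log units; beyond the scatter). Phenoxymethyl in place of piperidin-1-yl, on a saturated chain carbon bound to an amide-type nitrogen, is the first change in the series to go beyond the scatter, here towards lower toxicity in this test. The reading for compound 4 is a limit of the assay, not a number: the limit of > 500000 nM in this assay, at which 1 of the 4 values shown sits.

The compounds shown do not separate the roles of the aromatic ring, the chain oxygen and the longer chain in 2-phenoxyethyl; a 2-(piperidin-1-yl)ethyl or a 3-phenylpropyl group on the amide nitrogen would bear on this. From the compounds shown here alone, it also remains open whether bromo or chloro in place of nitro stays without effect once the 2-phenoxyethyl chain is present.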